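The source may hold more compounds than are shown below. What is called first, only, known or untested is meant among the compounds shown, and "the series" means these compounds.

Measured compounds in a functional assay on HeLa cells (Homo sapiens) for antiproliferative activity, read by CCK-8 assay, with a stated time of 72 h, tested at 8 uM; on this read-out lower numbers stand for a weaker effect and higher numbers for a stronger effect at the one concentration tested:
compound 1 `Nc1ccccc1NC(=O)c1ccc(CSC(=S)N2CCc3ccccc32)cc1`: 67%
compound 2 `CN(C(=S)SCc1ccc(C(=O)Nc2ccccc2N)cc1)c1cccnc1`: 70.5%
compound 3 `CC1CCCCN1C(=S)SCc1ccc(C(=O)Nc2ccccc2N)cc1`: 76.3%

Compound 3 carries the largest of the three numbers, but the steps of a number 5.8 percentage points higher from compound 2 to compound 3 (within the scatter) and a number 9.3 percentage points higher from compound 1 to compound 3 (within the scatter) both lie within the scatter, so no ranking is claimed.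

Compound 4 `CC1CCN(C(=S)SCc2ccc(C(=O)Nc3ccccc3N)cc2)CC1` differs from compound 3 as follows: 4-methylpiperidin-1-yl in place of 2-methylpiperidin-1-yl on a thiocarbonyl carbon.

Every measured step exchanges the group on the thiocarbonyl carbon, and each is small: a number 3.5 percentage points higher from compound 1 to compound 2 (within the scatter), a number 9.3 percentage points higher from compound 1 to compound 3 (within the scatter), a number 5.8 percentage points higher from compound 2 to compound 3 (within the scatter). None of them swaps two methylpiperidinyl groups, so the bearing is indirect. Since changes at this position have so far stayed within the scatter, the expected step of a number 2.3 percentage points lower from compound 3 to compound 4 (within the scatter) is likewise no change beyond the scatter. Compound 4 is estimated at 74%, with a range from 62% to 86%.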

Compound 4, a percentage reported as inhibition, at one concentration (the size of the read-out at that concentration, not a potency): 72.5%
For compound 4 the middle estimate is 1.5 percentage points above the measured one; low and high end bracket the measured number.
By their numbers in this assay, from the lowest: compounds 1, 2, 4 and 3 (each within the scatter of the next).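

In this assay, 4-methylpiperidin-1-yl in place of 2-methylpiperidin-1-yl on the thiocarbonyl carbon gives a number 3.8 percentage points lower from compound 3 to compound 4 (within the scatter) and so shows that two groups of the same atoms, joined differently, are not separated at this position. 4-Methylpiperidin-1-yl also stays level with the other two groups, with a number 2 percentage points higher from compound 2 to compound 4 (within the scatter) and a number 5.5 percentage points higher from compound 1 to compound 4 (within the scatter) in the same range. No measurement on hand speaks to the origin of these steps.

Still open, from the compounds shown here alone, is whether a morpholin-4-yl group or a plain dimethylamino group on the thiocarbonyl carbon would leave the scatter. Also open, going by these compounds, is whether the same four compounds separate at lower concentrations.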